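A few compounds are considered here, and "the series" means these few. Any claim that something is new, unique, unknown or untested is made for them only; others in the source may bear on it.

Three compounds have been measured in an ADME assay on Vero cells (Chlorocebus sabaeus) for cytotoxicity, read by MTT assay, with a stated time of 72 h; on this read-out higher numbers stand for lower toxicity in this test and lower numbers for higher toxicity in this test:

Compound 1 `COc1ccc(-c2cc(-c3ccc(C4NC(=O)c5ccccc5N4)cc3)nc(N)n2)cc1`: 124000 nM
Compound 2 `CC(C)c1ccc(C(Nc2ccc(C3(C)NC(=O)c4ccccc4N3)cc2)c2nnnn2C(C)(C)C)cc1`: > 400000 nM
Compound 3 `CC(C)(C)Nc1nc(Nc2ccc(C3(C)NC(=O)c4ccccc4N3)cc2)nc(NC(C)(C)C)n1`: 159000 nM

Compound 1 has the lowest of the two true numbers in this set, but the gap to its nearest neighbour, compound 3 at 159000 nM, lies within the usual scatter, so the two cannot be separated. The reading of > 400000 nM for compound 2 is a limit of the assay and not a number.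

Compound 4 `Nc1nc(-c2ccc(Cl)cc2)cc(-c2ccc(C3NC(=O)c4ccccc4N3)cc2)n1` has not yet been measured in this assay. It has chloro in place of methoxy on an aromatic carbon, para to a large group, turning the 4-methoxyphenyl of compound 1 into a 4-chlorophenyl (chloro in place of methoxy on an aromatic carbon). The core of compound 1 is otherwise unchanged.

Within the data shown here, no two measured compounds differ in one place only, so the data contain no direct precedent for this exchange. The expectation therefore starts from compound 1 at 124000 nM, and no change beyond the scatter is anticipated. The expected step is a 1.2-fold lower number from compound 1 to compound 4 (0.07 log units; within the scatter). For compound 4 the estimate is 105000 nM, with an expected range of 45000 nM to 240000 nM.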

Compound 4, half-maximal cytotoxic concentration: 323000 nM
Estimate against measurement, compound 4: 3.1-fold (0.49 log units) below, outside the stated range (above it).
By their numbers in this assay, from the lowest: compounds 1 and 3 (each within the scatter of the next); then compound 4. At a limit, above all of these: compound 2.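

In this assay, among these compounds, the change from 4-methoxyphenyl to 4-chlorophenyl gives the first step in this set between two compounds that differ in one place: a 2.6-fold higher number from compound 1 to compound 4 (0.42 log units; beyond the scatter). This shows that the aromatic carbon para to a large group is not indifferent in this test, since one exchange, with the core of compound 1 otherwise unchanged, moves the number beyond the scatter and towards lower toxicity in this test. The earlier compounds shown here differ from one another in more than one place, so they could not tie any change in the number to this position or to this exchange.

With only methoxy and chloro shown here, the result cannot tell whether the rise reflects the arrival of chloro or the departure of methoxy, and a compound with an unsubstituted phenyl, fluoro or a carboxylic acid at this position would help to separate the two. Any further rise at this position could soon meet the top of the read-out, where compound 2 stands as a limit and not as a number: the limit of > 400000 nM in this assay, at which 1 of the 4 values shown sits.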